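Amine alkylation step carried across two cores

The compounds below may be only part of what the source reports. "The series", "measured", "known", "first", "only" and "open" are said of these compounds alone.

Compound 1 `CNCC(=O)Nc1cc(OC)ccc1C(=O)c1ccc(OC)c2c1C=CC(C)(C)O2` gives 3460 nM in a functional assay on HCT-8 cells (Homo sapiens) for antiproliferative activity, read by MTT assay, with a stated time of 48 h; a lower number here means a stronger inhibitor, a higher number a weaker inhibitor. Compound 3 `CCNCC(=O)Nc1cc(OC)ccc1C(=O)c1ccc(OC)c2c1C=CC(C)(C)O2` gives 7890 nM in this assay; the change between them is methyl in place of hydrogen on a saturated chain carbon bound to an amine nitrogen, and the step is a 2.3-fold higher number from compound 1 to compound 3 (0.36 log units; beyond the scatter). Compound 2 `CNCC(=O)Nc1cc(OC)ccc1C(=O)c1ccc2c(c1)C=CC(C)(C)O2` gives 1010 nM in this assay, the lowest of the three values; how its core differs from that of compound 1 is not broken down here. Compound 4 `CCNCC(=O)Nc1cc(OC)ccc1C(=O)c1ccc2c(c1)C=CC(C)(C)O2` is not yet measured in this assay. Relative to compound 2 it carries the same change, (methyl in place of hydrogen on a saturated chain carbon bound to an amine nitrogen), at the same place. The expected step from compound 2 to compound 4 is a 2.3-fold higher number from compound 2 to compound 4 (0.36 log units; beyond the scatter). Going by the values given here, that expectation rests on the single earlier instance, because a 2.3-fold higher number from compound 1 to compound 3 (0.36 log units; beyond the scatter) went in that direction on the core of compound 1; no second example confirms it on the core of compound 2. Compound 4 is therefore estimated at 2300 nM in this assay, between 1200 nM and 4500 nM.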

Compound 4, half-maximal inhibitory concentration: 3990 nM
Beside the measured number, compound 4's estimate is 1.7-fold (0.24 log units) below it; measured number inside the range.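

The change from methylamino to ethylamino also gives a higher number on the second core, with a 4.0-fold higher number from compound 2 to compound 4 (0.60 log units; beyond the scatter), so in this assay the direction is the same on both cores shown. The two steps do not separate in size: the same change on two cores in this assay, a 2.3-fold higher number (0.36 log units; beyond the scatter) from compound 1 to compound 3 and a 4.0-fold higher number (0.60 log units; beyond the scatter) from compound 2 to compound 4, 1.7-fold (0.24 log units) apart, within the scatter of two such steps. This supports carrying the change between these two cores, in direction and within the scatter in size, but two pairs do not show that it would carry to any other core, and they do not explain why the number rises.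

Going by these compounds, whether a longer chain such as propyl, or a branched group such as isopropyl, would extend the same step remains open. So does the effect on either core of replacing the secondary amine with a cyclic amine such as pyrrolidine.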